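Swapping chloro for dimethylamino on a dienone scaffold

This account rests on a few compounds, and the source may have more. Where it says the series, first, only, none or still open, it means among the compounds named here.

Measured compounds:
- compound 1, `CN(C)c1ccc(/C=C2\CCC/C(=C\c3ccccc3[N+](=O)[O-])C2=O)cc1`: 4.86
- compound 2, `Cc1ccc(/C=C2\CCC/C(=C\c3cccc([N+](=O)[O-])c3)C2=O)cc1`: 5.06
- compound 3, `O=C1/C(=C/c2ccc(Cl)cc2)CCC/C1=C\c1cccc([N+](=O)[O-])c1`: 5.06

In a physicochemical assay for lipophilicity (on this read-out lower numbers stand for lower lipophilicity and higher numbers for higher lipophilicity), compound 3 gives 5.06. It stands level with compound 2 at the digits shown, together the highest of the three numbers, while compound 1 sits a little lower, a gap that lies within the scatter of repeated measurements.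

Compound 4, `CN(C)c1ccc(/C=C2\CCC/C(=C\c3cccc([N+](=O)[O-])c3)C2=O)cc1`, has not yet been measured in this assay. It differs from compound 3 in one place: dimethylamino in place of chloro on an aromatic carbon.

Among the compounds with values here, only one measured step concerns a change at that same aromatic carbon: no change at the digits printed from compound 2 to compound 3 (within the scatter). That step swapped one small group for another and left the number unchanged within the scatter. Within the data shown here, no measured pair isolates a dimethylamino for chloro exchange. Compound 1 does carry a dimethylamino group and reads somewhat lower than compound 3, yet it also places its nitro group differently, so its value can only hint at the direction.

Compound 4 is therefore expected to sit slightly below compound 3, with a step of a number 0.21 log units lower from compound 3 to compound 4 (within the scatter) that may not exceed the scatter. The estimate for compound 4 is 4.85, with a plausible range from 4.5 to 5.2.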

Compound 4, partition coefficient: 5.06
Compound 4: the middle estimate sits 0.21 log units below what was measured; measured number inside the range.
By their numbers in this assay, from the lowest: compounds 1, 2, 3 and 4 (each within the scatter of the next).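

In this assay, dimethylamino in place of chloro on the aromatic carbon gives no change at the digits printed from compound 3 to compound 4 (within the scatter) and the same group in place of methyl gives no change at the digits printed from compound 2 to compound 4 (within the scatter) as the measured outcome. Methyl, chloro and dimethylamino at this carbon therefore give readings within the scatter of one another, even though dimethylamino brings more heavy atoms and a hydrogen-bond acceptor that chloro lacks. With dimethylamino held fixed, moving from 2-nitrophenyl to 3-nitrophenyl gives a number 0.20 log units higher from compound 1 to compound 4 (within the scatter) and so also stays within the scatter.

Nothing available explains why these readings stay so close. On these data alone, whether the same holds at this carbon for a carboxylic acid or a longer chain stays open, as does whether the nitro group's place matters with chloro or methyl on the other ring.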